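The source may report more compounds than this note shows. Statements on the series, on what has been measured and on what is new or still open speak of the compounds shown alone.

Measured compounds:
compound 1, `CSc1nc2cnsc2[nH]1`: 32000 nM
compound 2, `Cc1nsc2[nH]c(SCc3ccccc3)nc12`: 10000 nM

Both numbers come from a functional assay on HFF cells (Homo sapiens) for inhibition; a higher number here means a weaker inhibitor, a lower number a stronger inhibitor. Compound 2 stands at the lower of the two values; compound 1 gives 32000 nM, a gap from compound 2 that lies beyond the usual scatter, so compound 2 is the stronger inhibitor of the two in this assay. Among the measured compounds shown here, no pair of measured compounds differs in a single place, so no step within the measured set can be read directly.

Compound 3, `c1ccc(CSc2nc3cnsc3[nH]2)cc1`, has not been measured in this assay. Set against compound 2 it shows (hydrogen in place of methyl on an aromatic carbon). For the measured compounds named here, nothing among the measured compounds speaks to what removing the methyl does on this core, so the expected step from compound 2 to compound 3 is worded with caution: a small move, likely toward a higher number, is expected, roughly at the edge of the scatter, a 1.6-fold higher number from compound 2 to compound 3 (0.20 log units; within the scatter).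

On that basis compound 3 is expected to give about 16000 nM in this assay, with a plausible range from 5000 nM to 50000 nM.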

Compound 3, half-maximal inhibitory concentration: 14000 nM
Compound 3: middle estimate off by 1.1-fold (0.06 log units), on the high side; the measured number falls inside the stated range.
By their numbers in this assay, from the lowest: compounds 2 and 3 (each within the scatter of the next); then compound 1.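

Notes on the methyl position: in this assay, hydrogen in place of methyl on an aromatic carbon of the five-membered aromatic ring with 1 nitrogen and 1 sulfur gives a 1.4-fold higher number from compound 2 to compound 3 (0.15 log units; within the scatter). Among the compounds shown here, this is the first single change that can be read directly, and it shows that the methyl can be removed from this place without a change beyond the scatter. For the compounds shown here, with the benzyl group on sulfur kept constant, the methyl is therefore not required to retain inhibition at this level, although the reading covers only this one change on this one scaffold. No measurement in hand explains why this position tolerates the change, and none bears on this result.

Only methyl and hydrogen are shown on this aromatic carbon, so the effect of an ethyl group, a phenyl ring, an amine or a carboxylic acid there remains open. Also open, from the compounds shown here alone, is whether a longer chain or a carboxylic acid in place of the benzyl group would give a number beyond the scatter of these values.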